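The source may hold more compounds than are shown below. What is called first, only, known or untested is meant among the compounds shown, and "the series" means these compounds.

Compound 2 `CC(C)(C)c1cc(NC(=O)[C@@H]2CCCCN2C(=O)C2CCCCC2)no1` gives the higher of the two half-lives recorded so far in an ADME assay (liver) for metabolic stability, with Liver microsome (Homo sapiens) as the target, read by LC-MS, using microsomes and NADPH, tested at 1 uM (a lower number here means that the compound disappears faster, a higher number that the compound lasts longer), at 0.483 h; compound 1 `CC(C)CN1CCCC[C@H]1C(=O)Nc1cc(C(C)(C)C)on1` gives 0.1 h, and the step of a 4.8-fold higher number from compound 1 to compound 2 (0.68 log units; beyond the scatter) came with cyclohexylcarbonyl in place of isobutyl on an amine nitrogen in a ring. Compound 3 `CC(C)(C)c1cc(NC(=O)[C@@H]2CCCCN2C(=O)CC2CCOCC2)no1` differs from compound 2 by (oxan-4-yl)methyl in place of cyclohexyl on a carbonyl carbon. Among the compounds with values here, no measured step touches this part of the molecule, so the one measured step offers no direct guide. The change is therefore expected to stay within the usual scatter, a 1.2-fold lower number from compound 2 to compound 3 (0.08 log units; within the scatter). Compound 3 is estimated at 0.4 h, with a range from 0.15 h to 1 h.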

Compound 3, half-life: 1.83 h
Compound 3: the middle estimate sits 4.6-fold (0.66 log units) below what was measured, outside the stated range (above it).
By their numbers in this assay, from the lowest: compound 1; then compound 2; then compound 3.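

In this assay, within the data shown here, the group on the carbonyl carbon matters: (oxan-4-yl)methyl in place of cyclohexyl gives a 3.8-fold higher number from compound 2 to compound 3 (0.58 log units; beyond the scatter), the first measured change at this position. Replacing isobutyl on the amine nitrogen in the ring with ((oxan-4-yl)methyl)carbonyl gives an 18-fold higher number from compound 1 to compound 3 (1.26 log units; beyond the scatter), the largest step shown. Nothing measured here explains this rise.

The new group differs from cyclohexyl by both a ring oxygen and a methyl link, and the compounds shown do not separate the two. Cyclohexylmethyl or oxan-4-yl on the same carbonyl carbon would separate them.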